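The source may report more compounds than this note shows. Statements on the series, on what has been measured and on what is new or still open speak of the compounds shown alone.

Of the compounds shown here, three built on one shared core have been measured in a physicochemical assay for acid dissociation. Compound 1 `COc1ccc(-c2ccc3c(NCCCNCc4cccc(OC)c4O)ccnc3c2)cc1` gives 9.47. Compound 3 `COc1cccc(CNCCCNc2ccnc3cc(Cc4cccc(C(F)(F)F)c4)ccc23)c1O` gives 9.47, and the step of no change at the digits printed from compound 1 to compound 3 (within the scatter) shows that putting 3-(trifluoromethyl)benzyl in place of 4-methoxyphenyl on an aromatic carbon of the core left the reading where it was. Compound 2 `FC(F)(F)c1ccc(-c2ccc3c(NCCCNCc4ccco4)ccnc3c2)cc1` gives 9.47, level with both of the others at the digits shown, so the three readings sit together with no order among them.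

Compound 4 `Fc1ccc(Cc2ccc3c(NCCCNCc4ccco4)ccnc3c2)c(Cl)c1` has not yet been measured. It differs from compound 2 in one place: 2-chloro-4-fluorobenzyl in place of 4-(trifluoromethyl)phenyl on an aromatic carbon. Among the measured compounds shown here, the only measured step that bears on this is the one from compound 1 to compound 3, which also exchanged the group on this aromatic carbon and stayed within the scatter. With all three readings at the same number, nothing in the data ties the acid dissociation constant to the group sitting on this carbon. Compound 4 is therefore expected to show a step of no change at the digits printed from compound 2 to compound 4 (within the scatter), that is, none beyond the scatter. The estimate for compound 4 in this assay is 9.47, with a range from 9.17 to 9.77.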

Compound 4, acid dissociation constant: 9.47
Estimate against measurement, compound 4: no gap at the digits printed; measured number inside the range.
By their numbers in this assay, from the lowest: compounds 1, 2, 3 and 4 (each within the scatter of the next).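

In this assay the exchange of 4-(trifluoromethyl)phenyl for 2-chloro-4-fluorobenzyl on this aromatic carbon leaves the reading in place (no change at the digits printed from compound 2 to compound 4 (within the scatter)). This gives a second exchange at this position with no readable effect, and it comes from a pair that carries a different group elsewhere in the molecule from the pair compound 1 and compound 3, so the earlier flat step no longer stands alone. The new group also brings chlorine and a single fluorine where the old one had three fluorines, yet the number stays the same, and nothing available accounts for this constancy.

Both groups in this step hold one six-membered aromatic ring of carbon only and have 0 hydrogen-bond donors and 0 hydrogen-bond acceptors, so the flat readings say nothing about a quite different kind of group on this carbon. An amine, a carboxylic acid or a longer chain at this position could still shift the reading in this assay, and the data here cannot tell whether it would.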